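Swapping the aroyl group on the acyl-urea of compound 2

The compounds below may be only part of what the source reports. "The series", "measured", "known", "first", "only" and "open" are said of these compounds alone.

Three close relatives share one core and were tested in a functional assay on HeLa cells (Homo sapiens) for inhibition, read by MTT assay, with a stated time of 72 h; on this read-out higher numbers stand for weaker inhibition and lower numbers for stronger inhibition. Compound 1 `CN(C(=O)NC(=O)c1cccc(C(F)(F)F)c1)c1nc(C(F)(F)F)c(C(=O)N/N=C/c2ccc(C(F)(F)F)cc2)s1` gives 7.35 ug/mL, compound 2 `CN(C(=O)NC(=O)c1cccc(C(F)(F)F)c1)c1nc(C(F)(F)F)c(C(=O)N/N=C/c2ccccc2C(F)(F)F)s1` gives 7.37 ug/mL, and compound 3 `CN(C(=O)NC(=O)c1ccc(C(F)(F)F)cc1)c1nc(C(F)(F)F)c(C(=O)N/N=C/c2cc(C(F)(F)F)cc(C(F)(F)F)c2)s1` gives 5.78 ug/mL. Compound 2 holds the greatest of the three numbers, yet its gaps to compound 1 and to compound 3 both fall inside the usual scatter, so no real difference among the three can be claimed. Going by the values given here, the one single-site step available, a 1.0-fold higher number from compound 1 to compound 2 (0.00 log units; within the scatter), concerns the aryl group attached to the carbon with a double bond to nitrogen and shows no change beyond the scatter.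

Compound 4 `CN(C(=O)NC(=O)c1c(Cl)cccc1Cl)c1nc(C(F)(F)F)c(C(=O)N/N=C/c2ccccc2C(F)(F)F)s1` is not yet measured. It differs from compound 2 at another place: 2,6-dichlorophenyl in place of 3-(trifluoromethyl)phenyl on a carbonyl carbon. Among the compounds with values here, no measured pair isolates a change at this carbonyl carbon, so the only guide is that the three measured values cluster closely despite varied aryl substitution. The expected outcome for compound 4 in this assay is therefore a 1.1-fold lower number from compound 2 to compound 4 (0.02 log units; within the scatter), no step beyond the scatter. Compound 4 is estimated at 7 ug/mL, within a range from 3.5 ug/mL to 15 ug/mL.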

Compound 4, half-maximal inhibitory concentration: 5.23 ug/mL
The estimate for compound 4 lay 1.3-fold (0.13 log units) above the measured number, within the range that was stated.
By their numbers in this assay, from the lowest: compounds 4, 3, 1 and 2 (each within the scatter of the next).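

Going by these compounds alone, this is the first single-site step at the carbonyl carbon of the acyl-urea. In this assay, 2,6-dichlorophenyl in place of 3-(trifluoromethyl)phenyl gives a 1.4-fold lower number from compound 2 to compound 4 (0.15 log units; within the scatter). At this position, then, one substituted phenyl ring can stand in for another, with different substituents, without a difference that can be told from the scatter, although this rests on a single pair. No supporting measurement is available to explain this result.

On these data alone, both groups at this position are substituted phenyl rings, so the effect of a ring-free group such as a short alkyl chain remains open. Also open, as far as these compounds go, is whether an aryl group carrying an amine or a carboxylic acid would move the number beyond the scatter.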